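The source may report more compounds than this note shows. Statements on the series, on what has been measured and on what is new or still open speak of the compounds shown alone.

Compound 1 `Cc1cccc(-n2nncc2CN2C(=O)C3(C(C#N)=C(N)Oc4c3c3nc5ccccc5nc3c3ccccc43)c3ccccc32)c1` — in a functional assay on HCT-116 cells (Homo sapiens) for antiproliferative activity, read by MTT assay, with a stated time of 48 h (on this read-out lower numbers stand for stronger inhibition and higher numbers for weaker inhibition), compound 1 reaches only the limit of the assay, > 50000 nM.
Compound 2 `Cc1ccc(-n2nncc2CN2C(=O)C3(C(C#N)=C(N)Oc4c3c3nc5ccccc5nc3c3ccccc43)c3ccccc32)cc1C` — in this assay compound 2 likewise gives only the limit > 50000 nM.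
Compound 3 `Cc1cc(C)cc(-n2nncc2CN2C(=O)C3(C(C#N)=C(N)Oc4c3c3nc5ccccc5nc3c3ccccc43)c3ccccc32)c1` — in this assay compound 3 again gives only the limit > 50000 nM.

Compound 1 thus stands at the ceiling of what this assay reports, not at a number; the same is true of the two further compounds, all three sitting at the limit described by the limit of > 50000 nM in this assay, at which 3 of the 3 values shown sit. The move to compound 4 `Cc1ccc(Cl)cc1-n1nncc1CN1C(=O)C2(C(C#N)=C(N)Oc3c2c2nc4ccccc4nc2c2ccccc32)c2ccccc21` is 5-chloro-2-methylphenyl in place of 3-methylphenyl on an aromatic nitrogen: the 3-methylphenyl leaves and a 5-chloro-2-methylphenyl enters on the aromatic nitrogen of the five-membered aromatic ring with three nitrogens.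

The measured steps that touch this position are a step that the two limits leave unreadable from compound 1 to compound 2, a step that the two limits leave unreadable from compound 1 to compound 3 and a step that the two limits leave unreadable from compound 2 to compound 3; none of them can be sized, since both ends lie at the limit. They show only that adding or moving a methyl on that phenyl brought nothing measurable. For compound 4 the expected step is therefore a step that the limit leaves unreadable from compound 1 to compound 4, that is, none beyond the scatter. Compound 4 is estimated at 60000 nM, within 20000 nM to 200000 nM, most likely again reported only as a limit.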

Compound 4, half-maximal inhibitory concentration: > 50000 nM
Compound 4 ended at the assay's limit; the forecaster's own chance of this, stated with the estimate: 85%; the middle value does not contradict the limit.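

Compound 4 stands with compound 1, compound 2 and compound 3 at one limit, so no step among these compounds can be read: the limit of > 50000 nM in this assay, at which 4 of the 4 values shown sit.

The compounds shown leave open what actual value any of the four has in this assay, and whether any change to the group on the aromatic nitrogen alters it.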